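The compounds below may be only part of what the source reports. "The series", "measured", "known", "first", "only" and "open" are said of these compounds alone.

Measured so far:
- Compound 1 `CN(C)c1ncnc2[nH]cc(Sc3cccs3)c12`: 3830 nM
- Compound 2 `CNc1ncnc2[nH]cc(Sc3cccs3)c12`: 4950 nM

In a functional assay on K562 cells (Homo sapiens), read by MTT assay, with a stated time of 3 days (a lower number here means a stronger inhibitor, a higher number a weaker inhibitor), compound 2 gives 4950 nM, and compound 1 gives 3830 nM. These two values lie within the scatter of each other, so neither compound can be ranked above the other. Compound 3 `Nc1ncnc2[nH]cc(Sc3cccs3)c12` keeps the shared core and changes one place in compound 2: hydrogen in place of methyl on a nitrogen on an aromatic ring. Its methylamino becomes amino, with hydrogen in place of methyl on a nitrogen on an aromatic ring. Within the data shown here, only one measured step is of the same kind: a 1.3-fold higher number from compound 1 to compound 2 (0.11 log units; within the scatter). It is a single step, and it starts from a different substitution on that nitrogen, so it offers limited guidance. No shift beyond the scatter is expected in this assay, and the estimated change is a 1.0-fold higher number from compound 2 to compound 3 (0.00 log units; within the scatter). For compound 3, the expected value is 5000 nM, with an estimated range from 2000 nM to 12000 nM.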

Compound 3, half-maximal inhibitory concentration: 17900 nM
Compound 3: the middle estimate sits 3.6-fold (0.55 log units) below what was measured, outside the stated range (above it).
By their numbers in this assay, from the lowest: compounds 1 and 2 (each within the scatter of the next); then compound 3.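

In this assay, the hydrogen-for-methyl change on a nitrogen on an aromatic ring proves to depend on what else that nitrogen carries: the first such change stays within the scatter, at a 1.3-fold higher number from compound 1 to compound 2 (0.11 log units; within the scatter), while the methylamino to amino change gives a 3.6-fold higher number from compound 2 to compound 3 (0.56 log units; beyond the scatter). The amino in place of dimethylamino change gives a 4.7-fold higher number from compound 1 to compound 3 (0.67 log units; beyond the scatter), so among these three compounds, the two with at least one methyl on that nitrogen stand together and the one with none stands apart. Nothing given here accounts for this difference.

The compounds shown leave open whether an ethyl group or a longer chain on that nitrogen would stay with compound 1 and compound 2 or move with compound 3. They also leave open how a cyclic amine such as morpholine would compare at this place.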